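Swapping a phenoxy for a dimethylbenzyl on the shared core

This account rests on a few compounds, and the source may have more. Where it says the series, first, only, none or still open, it means among the compounds named here.

Compound 1: `c1ccc(Oc2ccc3c(NCCCNCc4ccco4)ccnc3c2)cc1` gives 9.28 in a physicochemical assay for acid dissociation.
Compound 2: `COc1cccc(CNCCCNc2ccnc3cc(Oc4ccc(F)cc4)ccc23)c1O` gives 9.28 in this assay.
Compound 3: `COc1cccc(CNCCCNc2ccnc3cc(CCC(C)C)ccc23)c1O` gives 9.47 in this assay.

Compound 1 stands level with compound 2 at the digits shown, and the two are together the lowest of the three numbers; compound 3 sits a number 0.19 log units higher from compound 2 to compound 3 (within the scatter), which is within the scatter. The unmeasured compound 4 is `Cc1cc(C)cc(Cc2ccc3c(NCCCNCc4ccco4)ccnc3c2)c1`. It differs from compound 1 in one place: 3,5-dimethylbenzyl in place of phenoxy on an aromatic carbon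

For the measured compounds named here, the only measured step that bears on this is the one between compound 2 and compound 3, where an oxygen-linked aromatic substituent gave way to an all-carbon chain on the same kind of position and the acid dissociation constant moved by a number 0.19 log units higher from compound 2 to compound 3 (within the scatter), within the scatter. The change from compound 1 to compound 4 likewise replaces an oxygen-linked aromatic group with an all-carbon one, so no movement beyond the scatter is expected in this assay, perhaps a slight drift upward.

Compound 4 is therefore expected to give about 9.4 in this assay, between 9.05 and 9.75. That expectation amounts to a number 0.12 log units higher from compound 1 to compound 4 (within the scatter).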

Compound 4, acid dissociation constant: 9.47
Compound 4: middle estimate off by 0.07 log units, on the low side; the measured number falls inside the stated range.
By their numbers in this assay, from the lowest: compounds 1, 2, 3 and 4 (each within the scatter of the next).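

In this assay, 3,5-dimethylbenzyl in place of phenoxy on this aromatic carbon gives a number 0.19 log units higher from compound 1 to compound 4 (within the scatter) and so shows that this exchange, like the earlier one, stays inside the scatter. The earlier step had isopentyl entering, with no aromatic ring in the new group, whereas here the six-membered aromatic ring is kept, the oxygen goes and the hydrogen-bond acceptor of phenoxy goes with it, on the side chain of compound 1 rather than that of compound 2. No supporting measurement is available to explain this result.

Still open, on these data alone, is whether an amine or a carboxylic acid on this carbon would move the number beyond the scatter. Also open, as far as these compounds go, is what a longer chain carrying the same aromatic ring at this place would give in this assay.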